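The compounds below may be only part of what the source reports. "The series", "measured", "known", "first", "only" and "open" are said of these compounds alone.

Compound 1, `CN(C)CCn1cc(S(=O)(=O)c2ccccc2)c2cccnc21`: 94%
Compound 2, `Cc1c(S(=O)(=O)c2ccccc2)c2cccnc2n1CCN`: 85%

Both compounds were tested in a functional assay on HeLa cells for agonist activity at 5-hydroxytryptamine receptor 6 (Homo sapiens), read by immunoassay; on this read-out higher numbers stand for larger maximal responses and lower numbers for smaller maximal responses. Compound 2 sits at the bottom of this pair of numbers, but compound 1 lies close enough that the gap between them falls within the usual scatter of the assay, so the two cannot be told apart on these numbers alone.

The step of interest leads from compound 2 to compound 3, `Cc1c(S(=O)(=O)c2ccccc2)c2cccnc2n1CCN(C)C`, which has not yet been measured. The change is dimethylamino in place of amino on a saturated chain carbon, two bonds along the chain from an aromatic nitrogen. Put simply, the basic end of the side chain keeps its nitrogen, and two methyl groups are added to it.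

Going by the values given here, no measured pair in this set shows this exact change on its own, so the size of the step is not known. Compound 1 carries a dimethylamino group on its own side chain and gives a large response in this assay, which suggests the change does not cost much of the maximal response. The expected step from compound 2 to compound 3 is small, a number 5 percentage points higher from compound 2 to compound 3 (within the scatter), most likely within the scatter. For compound 3 the estimate in this assay is 90%, with a likely range from 76% to 100%.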

Compound 3, largest response reached (Emax), in percent of the reference or control that the assay uses: 100%
Estimate against measurement, compound 3: 10 percentage points below; low and high end bracket the measured number.
By their numbers in this assay, from the lowest: compounds 2, 1 and 3 (each within the scatter of the next, the first and the last beyond it).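

In this assay, going by these compounds alone, dimethylamino in place of amino on the side chain gives a number 15 percentage points higher from compound 2 to compound 3 (beyond the scatter), so this change, seen here on its own for the first time, raises the maximal response rather than costing any of it at this place. The second step, methyl in place of hydrogen on an aromatic carbon, gives a number 6 percentage points higher from compound 1 to compound 3 (within the scatter), so with dimethylamino on the chain, the compounds with and without this methyl cannot be told apart on this read-out. Nothing available here speaks to why the response moves with the change on the side chain.

Still open, on these data alone, is how the response behaves with methylamino, the halfway point on the same nitrogen, or with the amine closed into a ring, as in pyrrolidine or piperidine. It is also unknown whether a longer chain, such as 3-(dimethylamino)propyl, holds the response, and whether the gain from dimethylamino over amino would also appear on the core without the methyl group.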